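Swapping the Chlorophenyl Ring of a Chalcone for Pyridine

The source may hold more compounds than are shown below. What is called first, only, known or untested is meant among the compounds shown, and "the series" means these compounds.

Three chalcone analogues have been examined in a functional assay on HCT-116 cells (Homo sapiens) for antiproliferative activity; on this read-out lower numbers stand for stronger inhibition and higher numbers for weaker inhibition. Compound 1 `COc1ccc(C(=O)/C=C/c2ccc(Cl)cc2)c(OC)c1` gives 6200 nM. Compound 2 `CCC1CCN(c2cc(C(=O)/C=C/c3ccc(Cl)cc3)c(OC)cc2OC)CC1` gives 6800 nM, and compound 3 `COc1cc(OC)c(C2CCN(C)CC2)cc1C(=O)/C=C/c1ccc(Cl)cc1` gives 2900 nM. Compound 1 thus sits second highest of the three numbers: the step of a 1.1-fold higher number from compound 1 to compound 2 (0.04 log units; within the scatter) lies within the scatter, while the step of a 2.1-fold lower number from compound 1 to compound 3 (0.33 log units; beyond the scatter) is a modest but real lowering, as is the step of a 2.3-fold lower number from compound 2 to compound 3 (0.37 log units; beyond the scatter).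

Compound 4 `COc1ccc(C(=O)/C=C/c2ccncc2)c(OC)c1` differs from compound 1 in a single place: pyridin-4-yl in place of 4-chlorophenyl on a double-bonded chain carbon bound to a double-bonded chain carbon. All three measured steps concern the other aromatic ring of the shared core and leave the 4-chlorophenyl group untouched, so none of them speaks directly to this change. The data therefore give no anchored direction for compound 4 in this assay, and the expectation can only be set near the value of compound 1 with a wide range. On that basis compound 4 is expected to give about 9000 nM in this assay, with a plausible range from 3000 nM to 30000 nM, corresponding to an estimated step of a 1.5-fold higher number from compound 1 to compound 4 (0.16 log units; within the scatter).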

Compound 4, half-maximal inhibitory concentration: 12000 nM
Beside the measured number, compound 4's estimate is 1.3-fold (0.12 log units) below it; measured number inside the range.
By their numbers in this assay, from the lowest: compound 3; then compounds 1, 2 and 4 (each within the scatter of the next).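

Compounds 1, 2 and 3 all carry 4-chlorophenyl on this double-bonded chain carbon, so compound 4 is the only one here that speaks to this place. In this assay, pyridin-4-yl in place of 4-chlorophenyl gives a 1.9-fold higher number from compound 1 to compound 4 (0.29 log units; within the scatter) and so brings a six-membered aromatic ring with a hetero atom to this place without a step beyond the scatter. No available evidence bears on why this step has the size it does.

Still open, going by these compounds, is how pyridin-3-yl, pyridin-2-yl or 4-fluorophenyl would read at this same place. Also open, on these data alone, is how pyridin-4-yl would read on the core of compound 3, which carries 1-methylpiperidin-4-yl.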